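The compounds below may be only part of what the source reports. "The series", "measured", "known", "first", "only" and "open" are said of these compounds alone.

Measured in a functional assay on A549 cells (Homo sapiens) for antiproliferative activity, read by spectrophotometry, with a stated time of 2 days; a lower number here means a stronger inhibitor of growth, a higher number a weaker inhibitor of growth:
- Compound 1 `Cc1cc(C)cc(Nc2ncc(C(F)(F)F)c(N3Cc4cccc(N(C)S(C)(=O)=O)c4C3)n2)c1`: > 30000 nM
- Compound 2 `COc1cc(Nc2ncc(C(F)(F)F)c(N3Cc4cccc(N(C)S(C)(=O)=O)c4C3)n2)cc(C(F)(F)F)c1`: > 30000 nM

Both entries are limits and not numbers, as the limit of > 30000 nM in this assay, at which 2 of the 2 values shown sit, shows. In this assay compound 2 gives > 30000 nM, which is a limit. Within the data shown here, the one measured step, a step that the two limits leave unreadable from compound 1 to compound 2, therefore offers no size to carry forward.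

Compound 3 `CN(c1cccc2c1CN(c1nc(Nc3ccc(Cl)c(C(F)(F)F)c3)ncc1C(F)(F)F)C2)S(C)(=O)=O` differs from compound 2 as follows: 4-chloro-3-(trifluoromethyl)phenyl in place of 3-methoxy-5-(trifluoromethyl)phenyl on a nitrogen on an aromatic ring. With no readable step as a guide, only a modest gain in growth inhibition is expected, and another limit is quite possible. The expected change is an at least 1.5-fold lower number from compound 2 to compound 3 (0.17 log units; that floor lies within the scatter). The estimate for compound 3 is 20000 nM, with an expected range of 4000 nM to 30000 nM.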

Compound 3, concentration for 50% growth inhibition: 15200 nM
The estimate for compound 3 lay 1.3-fold (0.12 log units) above the measured number; low and high end bracket the measured number.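

In this assay, compound 3 shows that a change to the aromatic ring on this nitrogen can give a readable number, which neither earlier compound gave. The 4-chloro-3-(trifluoromethyl)phenyl group gives an at least 1.9-fold lower number from compound 2 to compound 3 (0.29 log units; that floor lies within the scatter), and in place of 3,5-dimethylphenyl it gives an at least 1.9-fold lower number from compound 1 to compound 3 (0.29 log units; that floor lies within the scatter). Both steps are only floors, and their true size stays unknown: the limit of > 30000 nM in this assay, at which 2 of the 3 values shown sit.

The compounds shown leave open whether the chlorine alone accounts for the number of compound 3. They also leave open whether an amine or a carboxylic acid on this ring would lower the number further.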